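Pyrimidinyl to 4-Methoxyphenyl: What to Expect for Compound 4

This account rests on a few compounds, and the source may have more. Where it says the series, first, only, none or still open, it means among the compounds named here.

Measured so far in a functional assay (brain) for inhibition, with Rattus norvegicus as the target; on this read-out higher numbers stand for weaker inhibition and lower numbers for stronger inhibition:
compound 1 `COc1ccccc1N1CCN(C(=O)C2(C)CCc3c(C)c(O)c(C)c(C)c3O2)CC1` gives 15000 nM
compound 2 `Cc1c(C)c2c(c(C)c1O)CCC(C)(C(=O)N1CCN(c3ccccn3)CC1)O2` gives 1000 nM
compound 3 `Cc1c(C)c2c(c(C)c1O)CCC(C)(C(=O)N1CCN(c3ncccn3)CC1)O2` gives 23000 nM

Compound 3 has the highest number of the three in this assay, yet its gap to compound 1 is small: a 1.5-fold higher number from compound 1 to compound 3 (0.19 log units; within the scatter), within the scatter. Its gap to compound 2 is another matter: a 23-fold higher number from compound 2 to compound 3 (1.36 log units; beyond the scatter), and likewise a 15-fold lower number from compound 1 to compound 2 (1.18 log units; beyond the scatter), both beyond the scatter. Only the pyridin-2-yl compound stands apart on these numbers.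

Compound 4 `COc1ccc(N2CCN(C(=O)C3(C)CCc4c(C)c(O)c(C)c(C)c4O3)CC2)cc1` is not yet measured. It differs from compound 3 in one place: 4-methoxyphenyl in place of pyrimidin-2-yl on an amine nitrogen in a ring. Among the measured compounds shown here, no measured step exchanges a pyrimidin-2-yl for a methoxyphenyl of this kind, and no step moves a methoxy group around the ring. The closest guide is that compound 1, also carrying a methoxyphenyl, and compound 3 sit within the scatter of each other in this assay. A step of modest size toward a lower number is therefore expected, near compound 1, as a 2.3-fold lower number from compound 3 to compound 4 (0.36 log units; beyond the scatter). Compound 4 is expected to give 10000 nM in this assay, with a range from 2000 nM to 50000 nM.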

Compound 4, half-maximal inhibitory concentration: 700 nM
For compound 4 the middle estimate is 14-fold (1.15 log units) above the measured one; measured number outside the range, below it.
By their numbers in this assay, from the lowest: compounds 4 and 2 (each within the scatter of the next); then compounds 1 and 3 (each within the scatter of the next).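

In this assay the two methoxyphenyl compounds do not go together: a 21-fold lower number from compound 1 to compound 4 (1.33 log units; beyond the scatter) shows that carrying a methoxyphenyl on this amine nitrogen does not by itself set the number, since 4-methoxyphenyl and 2-methoxyphenyl part widely here. The change from pyrimidin-2-yl is just as large, with a 33-fold lower number from compound 3 to compound 4 (1.52 log units; beyond the scatter) on a group with one six-membered aromatic ring of carbon only, while a 1.4-fold lower number from compound 2 to compound 4 (0.15 log units; within the scatter) places the 4-methoxyphenyl and pyridin-2-yl compounds within the scatter of each other, so pyridin-2-yl no longer stands alone among the low numbers. No measurement at hand explains why these groups differ.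

From the compounds shown here alone, it remains open whether the methoxy group itself matters, as a plain phenyl group or a 4-chlorophenyl group on the same nitrogen would show. A 4-ethoxyphenyl group would test whether a longer chain on the oxygen is tolerated.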